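Swapping a fluorinated ring for a chlorinated one on a piperazine

The source may report more compounds than this note shows. Statements on the series, on what has been measured and on what is new or still open speak of the compounds shown alone.

Measured compounds:
compound 1, `CCCc1nc(-c2ccccc2)c(CNCCCN2CCN(c3ccccc3F)CC2)o1`, 54.4%
compound 2, `CCCc1nc(-c2ccccc2)c(CNCCN2CCN(c3ccccc3C)CC2)o1`, 51.3%

In an assay on HEK293 cells for inhibition of Voltage-dependent T-type calcium channel subunit alpha-1G (Homo sapiens), read by fluorescence, tested at 10 uM (a lower number here means less inhibition, a higher number more inhibition at the concentration tested (going by the name of the read-out)), compound 1 gives 54.4%, the higher of the two numbers recorded. Its nearest neighbour, compound 2, gives 51.3% in this assay, and the gap between the two lies within the usual scatter of repeated measurements, so the two compounds cannot be told apart on these data.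

Compound 3, `CCCc1nc(-c2ccccc2)c(CNCCCN2CCN(c3ccc(Cl)cc3)CC2)o1`, has not been measured yet. It differs from compound 1 in one place: 4-chlorophenyl in place of 2-fluorophenyl on an amine nitrogen in a ring. Both groups that leave and enter are single aromatic rings carrying one halogen, and neither adds or removes any hydrogen-bond donor or acceptor.

Among the measured compounds shown here, no measured pair shows what such a change does in this assay, and the only two numbers at hand sit within the scatter of one another. The expectation is therefore a step of a number 2.4 percentage points lower from compound 1 to compound 3 (within the scatter), that is, no change beyond the scatter in either direction. On that basis compound 3 is estimated to give 52% in this assay, with a plausible range from 35% to 70%.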

Compound 3, a percentage reported as inhibition, at one concentration (the size of the read-out at that concentration, not a potency): 63.3%
Compound 3: middle estimate off by 11.3 percentage points, on the low side; the measured number falls inside the stated range.
By their numbers in this assay, from the lowest: compounds 2, 1 and 3 (each within the scatter of the next, the first and the last beyond it).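

Here a number 8.9 percentage points higher from compound 1 to compound 3 (within the scatter) in this assay, the first step read at this position, on an amine nitrogen in a ring. Two groups of 7 heavy atoms, each a single aromatic ring with one halogen, therefore cannot be told apart on these data, so the number is level with 2-fluorophenyl and 4-chlorophenyl as far as this one pair shows, even though both the halogen and its place on the ring differ. Nothing measured on these compounds bears on why the step came out this way.

This single step changes two things at once, so it leaves open what the halogen and its place on the ring each contribute; 2-chlorophenyl or 4-fluorophenyl would be the compounds to separate them, since each differs from compound 1 or compound 3 in only one of the two. It also leaves open whether groups of a different kind at this position, such as an unsubstituted phenyl, a pyridine ring or a 4-methoxyphenyl, give a level number, or whether a step beyond the scatter appears with any of them.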